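Side-chain amine replacements: Vero cytotoxicity notes

The source may report more compounds than this note shows. Statements on the series, on what has been measured and on what is new or still open speak of the compounds shown alone.

The series shares the core of compound 1 `COc1ccc2[nH]c(C(=O)N3CC(=O)N(Cc4ccccc4)[C@@H](COCc4ccccc4)C3)cc2c1` and varies the group on the saturated chain carbon bound to a saturated ring carbon. In an ADME assay on Vero cells (Chlorocebus sabaeus) for cytotoxicity, with a stated time of 7 days (on this read-out higher numbers stand for lower toxicity in this test and lower numbers for higher toxicity in this test), compound 1 sits at a limit of the assay, > 30000 nM. Compound 2 `COc1ccc2[nH]c(C(=O)N3CC(=O)N(Cc4ccccc4)[C@@H](COC(C)(C)C)C3)cc2c1` carries tert-butyl in place of benzyl on an oxygen on a saturated carbon, and in this assay compound 2 gives 78200 nM. Compound 3 `COc1ccc2[nH]c(C(=O)N3CC(=O)N(Cc4ccccc4)[C@@H](CN4CCN(c5ccccn5)CC4)C3)cc2c1` carries 4-(pyridin-2-yl)piperazin-1-yl at the same position. In this assay compound 3 also sits at a limit of the assay, > 30000 nM. The steps a step that the two limits leave unreadable from compound 1 to compound 3 and a step that the limit leaves unreadable from compound 2 to compound 3 therefore have no readable size, nor does a step that the limit leaves unreadable from compound 1 to compound 2, given (the limit of > 30000 nM in this assay, at which 2 of the 3 values shown sit). Compound 4 `COc1ccc2[nH]c(C(=O)N3CC(=O)N(Cc4ccccc4)[C@@H](CN4CCCc5ccccc54)C3)cc2c1` differs from compound 3 by 1,2,3,4-tetrahydroquinolin-1-yl in place of 4-(pyridin-2-yl)piperazin-1-yl on a saturated chain carbon bound to a saturated ring carbon. With every measured step unreadable, the numbers shown offer no direction for this change, and none of the three values indicates toxicity within the range tested. The step from compound 3 to compound 4 is expected to be a step that the limit leaves unreadable from compound 3 to compound 4, nothing beyond the scatter. Compound 4 is expected at 60000 nM, between 25000 nM and 150000 nM, with a fair chance that only a limit is reported again.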

Compound 4, half-maximal cytotoxic concentration: > 100000 nM
Compound 4: a limit, no number; the forecaster's own chance of this, stated with the estimate: 60%; middle value at least 1.6-fold (0.22 log units) from the limit.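

In this assay compound 4 gives > 100000 nM, which is a limit of the assay and not a number. Going by these compounds alone, on a saturated chain carbon bound to a saturated ring carbon, 1,2,3,4-tetrahydroquinolin-1-yl, with its six-membered aromatic ring of carbon only, therefore joins the other groups in showing no measured toxicity within the range tested, and the one readable comparison gives an at least 1.2-fold higher number from compound 2 to compound 4 (0.10 log units; that floor lies within the scatter), so no rise beyond the scatter is established. The remaining steps to compound 4 cannot be read, since each runs between two limits: the limit of > 30000 nM in this assay, at which 2 of the 4 values shown sit.

The compounds shown give no number for any amine at this place, so no ranking of these groups can be drawn. Also open, as far as these compounds go, is how a smaller amine such as morpholin-4-yl, or a carboxylic acid on the same chain carbon, would read in this assay.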